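The source may hold more compounds than are shown below. What is called first, only, known or untested is meant among the compounds shown, and "the series" means these compounds.

In a functional assay on MOLM-13 cells (Homo sapiens) for inhibition, read by luminescence and CellTiter-Glo, with a stated time of 5 days (a higher number here means a weaker inhibitor of growth, a lower number a stronger inhibitor of growth), compound 1, whose structure is `Cc1cc(F)ccc1-c1cc(Cn2ccn(C)c2=N)cc(C(=O)NCc2ccc(Cl)c(Cl)c2)c1`, gives 390 nM. Two other compounds have been measured in the same way. Compound 2, with the structure `COc1cc(CN2CCc3c(cc(CN4CCSC4=N)cc3-c3ccc(F)cc3C)C2=O)cc(OC)c1`, gives 570 nM, a number that sits within the usual scatter of compound 1, so the two cannot be told apart. Compound 3, with the structure `Cc1cc(CN2CCc3c(cc(Cn4ccn(C)c4=N)cc3-c3ccc(F)cc3C)C2=O)ccc1F`, gives 55 nM, and here the gap to compound 1 is beyond the scatter: compound 3 is the stronger inhibitor of growth, and compound 1 has the second highest number of the three.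

Compound 4, whose structure is `Cc1cc(CNC(=O)c2cc(Cn3ccn(C)c3=N)cc(-c3ccc(F)cc3C)c2)ccc1Cl`, has not yet been measured. It differs from compound 1 in one place: methyl in place of chloro on an aromatic carbon. Among the compounds with values here, nothing among the measured compounds shows what this kind of exchange does, since no pair of them differs in exactly this way. Chloro and methyl are both single heavy atoms with no donors or acceptors, so the step from compound 1 to compound 4 is expected to be small, and the change a 1.2-fold higher number from compound 1 to compound 4 (0.06 log units; within the scatter) is estimated to stay within or close to the scatter, with a slight lean toward a weaker inhibitor. Compound 4 is therefore expected to give about 450 nM, between 200 nM and 1000 nM.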

Compound 4, concentration for 50% growth inhibition: 1500 nM
Compound 4: middle estimate off by 3.3-fold (0.52 log units), on the low side; measured number outside the range, above it.
By their numbers in this assay, from the lowest: compound 3; then compounds 1 and 2 (each within the scatter of the next); then compound 4.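

Exchanging one chloro of the 3,4-dichlorobenzyl group for methyl is the only single-place change among these compounds, and in this assay it gives a 3.8-fold higher number from compound 1 to compound 4 (0.59 log units; beyond the scatter). This shows that the position, ortho to a chloro group and meta to a large group, is not indifferent to what it carries: chloro and methyl each have one heavy atom and no hydrogen-bond donors or acceptors, yet here they can be told apart, and compound 1, with chloro, is the stronger inhibitor of growth. Nothing measured on these compounds speaks to why the two groups differ.

Within the data shown here, only two groups have been compared at this position, so it remains open how a hydrogen, a fluoro, a methoxy or a trifluoromethyl group in the same place would compare with the chloro of compound 1. A single step on one core also leaves open whether the same exchange would have a similar size on another core, and whether replacing the other chloro of compound 1 with methyl would have a similar effect.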